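Working notes: compound 2 and its non-aromatic ring analogue

The source may hold more compounds than are shown below. What is called first, only, known or untested is meant among the compounds shown, and "the series" means these compounds.

compound 1 `CCCCc1cc(-c2ccccc2OCc2ccc(OC)cc2)no1`: > 300000 nM
compound 2 `COc1cccc(COc2ccccc2-c2cc(CO)on2)c1`: 72000 nM

Of the compounds shown here, two have been measured in an assay with Cystic fibrosis transmembrane conductance regulator (Rattus norvegicus) as the target; on this read-out higher numbers stand for weaker binding and lower numbers for tighter binding. Compound 1 gives only > 300000 nM, which is a limit of this assay and not a number, as recorded in the limit of > 300000 nM in this assay, at which 1 of the 2 values shown sits. Compound 2 gives 72000 nM in this assay, and this is the only number shown. Going by the values given here, the one further value, that of compound 1, is a limit. Among the compounds with values here, no step between two measured compounds that differ in a single place is available, so the scale of any structural change in this assay is unknown.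

Compound 3 `COc1cccc(COc2ccccc2C2=NOC(CO)C2)c1` differs from compound 2 by a group of 7 heavy atoms (4 carbon, 1 nitrogen, 2 oxygen; one five-membered non-aromatic ring with 2 hetero atoms) in place of a group of 7 heavy atoms (4 carbon, 1 nitrogen, 2 oxygen; one five-membered aromatic ring with 2 hetero atoms), on an aromatic carbon, in words a group of 7 heavy atoms (4 carbon, 1 nitrogen, 2 oxygen; one five-membered non-aromatic ring with 2 hetero atoms) in place of a group of 7 heavy atoms (4 carbon, 1 nitrogen, 2 oxygen; one five-membered aromatic ring with 2 hetero atoms), on an aromatic carbon, ortho to a large group.

With nothing measured on this kind of change, the step of a 1.4-fold higher number from compound 2 to compound 3 (0.14 log units; within the scatter) is expected to be small, at most a slight weakening, and possibly none beyond the scatter. For compound 3 the estimate in this assay is 100000 nM, with a range from 30000 nM to 400000 nM.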

Compound 3, dissociation constant: 115000 nM
For compound 3 the middle estimate is 1.2-fold (0.06 log units) below the measured one; low and high end bracket the measured number.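

In this assay, the non-aromatic five-membered ring in place of the 5-(hydroxymethyl)-1,2-oxazol-3-yl group, on an aromatic carbon ortho to a large group, gives a 1.6-fold higher number from compound 2 to compound 3 (0.20 log units; within the scatter). Going by these compounds alone, this is the first step that can be read between two compounds differing in one place, and it sets a first scale for a change at this position. Both groups have the same counts of heavy atoms, hydrogen-bond donors and hydrogen-bond acceptors, so the step tests ring type alone, and the read-out does not separate the aromatic ring from the non-aromatic one.

Compound 1 remains a limit and not a number, and it gives no size for any change: the limit of > 300000 nM in this assay, at which 1 of the 3 values shown sits. Going by these compounds, it remains open whether a carboxylic acid or an amine in place of the hydroxyl of the hydroxymethyl group would move the read-out beyond the scatter, and whether the same ring change would stay as small on a core carrying a different substituent.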